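A Single Inverted Stereocentre in Compound 3

A few compounds are considered here, and "the series" means these few. Any claim that something is new, unique, unknown or untested is made for them only; others in the source may bear on it.

In an ADME assay on a cell-free system (plasma, Homo sapiens) for protein binding, using equilibrium dialysis, with a stated time of 5 h, tested at 10 uM (a higher number here means a larger unbound share of the compound, a lower number a smaller unbound share), compound 1 (`CC[C@@H](c1ccc(C(=O)O)c(Oc2cccc(Cl)c2)c1F)N1CCC[C@H](n2cc(C)c(=O)[nH]c2=O)C1`) gives 0.011 and compound 2 (`Cc1cn([C@H]2CCCN([C@H](CC(C)C)c3ccc(C(=O)O)c(Oc4cccc(Cl)c4)c3F)C2)c(=O)[nH]c1=O`) gives 0.013 as its reading. These two values lie within the scatter of each other, so compound 2 stands level with compound 1. Compound 3 (`Cc1cn([C@H]2CCCN([C@@H](CC(C)C)c3ccc(C(=O)O)c(Oc4cccc(Cl)c4)c3F)C2)c(=O)[nH]c1=O`) has not yet been measured. Its relation to compound 2 is simple (the two compounds have the same atoms and bonds and differ only in configuration as drawn: 1 of 2 stereo elements differ; a stereocentre at a saturated chain carbon is drawn R in compound 2 and S in compound 3): the two have the same atoms and bonds, and a stereocentre at a saturated chain carbon is drawn R in compound 2 and S in compound 3. Going by the values given here, no measured pair here differs in configuration alone, so the data offer no direct guide. In this assay no step beyond the scatter is expected, in either direction. The expected change is no change at the digits printed from compound 2 to compound 3 (within the scatter) and no more. Compound 3 is estimated at 0.013 with 0.007 to 0.024 as the expected range.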

Compound 3, unbound fraction: 0.007
For compound 3 the middle estimate is 1.9-fold (0.27 log units) above the measured one, and the stated range covers the measured number.
By their numbers in this assay, from the lowest: compounds 3, 1 and 2 (each within the scatter of the next).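

Drawing the stereocentre at the saturated chain carbon as S rather than R gives a 1.9-fold lower number from compound 2 to compound 3 (0.27 log units; within the scatter) in this assay, the first reading of configuration alone at this position. Isopropyl in place of methyl on that chain carbon gives a 1.6-fold lower number from compound 1 to compound 3 (0.20 log units; within the scatter). Neither change at this carbon moves the unbound fraction beyond the scatter, and the first of them is a clean comparison of configuration: the fact that compounds 2 and 3 differ only in the configuration as drawn.

The compounds shown leave open whether a longer chain or a phenyl group on this carbon would give a step beyond the scatter. They also leave open what inverting the other stereocentre would do, and whether a primary amide in place of the carboxylic acid would shift the unbound fraction in this assay.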